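Swapping a Methoxy Group for Phenyl on a Urea Tail

A few compounds are considered here, and "the series" means these few. Any claim that something is new, unique, unknown or untested is made for them only; others in the source may bear on it.

Compound 1, `COc1cccc(NC(=O)Nc2ccc(Nc3ncnc4c3OCCN4)cc2)c1`: 5290 nM
Compound 2, `O=C(Nc1ccc(Nc2ncnc3c2OCCN3)cc1)Nc1cccc2ccccc12`: > 10000 nM

Both compounds were tested in an assay on isolated protein for inhibition of proto-oncogene tyrosine-protein kinase receptor Ret variant V804M (Homo sapiens), read by 33P incorporation, with stated times of 15 min and 40 min; on this read-out lower numbers stand for stronger inhibition and higher numbers for weaker inhibition. Going by the values given here, compound 1 gives 5290 nM, the only plain number among the two results. For compound 2 the assay returned no number but a limit, > 10000 nM. That result sits at the limit of > 10000 nM in this assay, at which 1 of the 2 values shown sits, so the step of an at least 1.8-fold higher number from compound 1 to compound 2 (0.27 log units; that floor lies within the scatter) is itself only a floor.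

Compound 3, `O=C(Nc1ccc(Nc2ncnc3c2OCCN3)cc1)Nc1cccc(-c2ccccc2)c1`, differs from compound 1 by phenyl in place of methoxy on an aromatic carbon. Among the compounds with values here, the one measured step that bears on it is an at least 1.8-fold higher number from compound 1 to compound 2 (0.27 log units; that floor lies within the scatter), where a different aryl group was placed on the amide-type nitrogen and the number moved up to the limit. Here another aromatic ring enters the same tail, so a weaker result is expected, with a 2.3-fold higher number from compound 1 to compound 3 (0.36 log units; beyond the scatter). Compound 3 is therefore estimated at 12000 nM, in a range from 4000 nM to 40000 nM, with a real chance that the assay again reports only a limit.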

Compound 3, half-maximal inhibitory concentration: 7590 nM
Beside the measured number, compound 3's estimate is 1.6-fold (0.20 log units) above it; the range from low to high includes it.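

Putting phenyl in place of methoxy on this aromatic carbon gives a 1.4-fold higher number from compound 1 to compound 3 (0.16 log units; within the scatter) in this assay. This position therefore takes on a six-membered aromatic ring of carbon only, and gives up the hydrogen-bond acceptor of methoxy, without a difference that this read-out can separate from ordinary repeat variation. Compound 2 remains a limit and not a number, so its distance from compound 3 cannot be read: the limit of > 10000 nM in this assay, at which 1 of the 3 values shown sits.

The compounds shown leave open what an amine or a carboxylic acid would do on this same aromatic carbon, as methoxy and phenyl both carry no net charge. They also leave open whether any group here could give much stronger inhibition than compound 1, which gives 5290 nM.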